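Methylsulfonyl for acetyl on the piperazine of compound 3

This account rests on a few compounds, and the source may have more. Where it says the series, first, only, none or still open, it means among the compounds named here.

Compound 1 `CCN(CC)c1ccc2cc(C(=O)c3ccc(N4CCN(C(=O)COc5ccc(Cl)cc5Cl)CC4)cc3)oc2c1`: in a functional assay on HeLa cells (Homo sapiens) for cytotoxicity, read by MTT assay, with a stated time of 48 h (on this read-out lower numbers stand for stronger inhibition and higher numbers for weaker inhibition), compound 1 gives 30 nM.
Compound 2 `CCN(CC)c1ccc2cc(C(=O)c3ccc(N4CCN(S(=O)(=O)c5ccc(F)cc5)CC4)cc3)oc2c1`: in this assay compound 2 gives 21600 nM.
Compound 3 `CCN(CC)c1ccc2cc(C(=O)c3ccc(N4CCN(C(C)=O)CC4)cc3)oc2c1`: in this assay compound 3 gives 5150 nM.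

Compound 3 stands second highest of the three numbers; its nearest neighbour is compound 2, while compound 1 lies far below it, as the step of a 170-fold higher number from compound 1 to compound 3 (2.23 log units; beyond the scatter) shows. Compound 4 `CCN(CC)c1ccc2cc(C(=O)c3ccc(N4CCN(S(C)(=O)=O)CC4)cc3)oc2c1` differs from compound 3 by one change: methylsulfonyl in place of acetyl on an amine nitrogen in a ring. Among the measured compounds shown here, no measured step changes acetyl to methylsulfonyl directly. The step of a 4.2-fold lower number from compound 2 to compound 3 (0.62 log units; beyond the scatter) replaces a sulfonyl group with acetyl on the same ring nitrogen and is modest, and the step of a 720-fold higher number from compound 1 to compound 2 (2.86 log units; beyond the scatter) shows that a sulfonyl on this nitrogen can sit far above an acyl group. The change to compound 4 is small in size, so a step in this assay of modest size toward a higher number is expected, with a step within the scatter not excluded. For compound 4 the estimate is 7500 nM, between 2500 nM and 22000 nM, an expected step of a 1.5-fold higher number from compound 3 to compound 4 (0.16 log units; within the scatter).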

Compound 4, half-maximal inhibitory concentration: > 40000 nM
Compound 4 was reported as a limit; the forecaster's own chance of this, stated with the estimate: 5%; middle value at least 5.3-fold (0.72 log units) away from the limit.
By their numbers in this assay, from the lowest: compound 1; then compound 3; then compound 2. At a limit, above all of these: compound 4.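

Compound 4 in this assay is a limit and not a number, so each step to it is a floor: the limit of > 40000 nM in this assay, at which 1 of the 4 values shown sits. Even so, the change from acetyl to methylsulfonyl on this ring nitrogen is a step beyond the scatter (an at least 7.7-fold higher number from compound 3 to compound 4 (0.89 log units; beyond the scatter)), showing that a small change at this position can move the number clearly, and the gap from the acylated compound widens further (an at least 1300-fold higher number from compound 1 to compound 4 (3.12 log units; beyond the scatter)). Methyl in place of 4-fluorophenyl on the sulfonyl sulfur gives a floor within the scatter (an at least 1.8-fold higher number from compound 2 to compound 4 (0.26 log units; that floor lies within the scatter)), so these two sulfonyl compounds cannot be firmly ordered. The compounds shown leave open how far the true value of compound 4 lies past the limit. They also leave open whether an amine or a longer chain on the sulfonyl sulfur would behave as methyl or 4-fluorophenyl do.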